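Amino to Dimethylamino on a Difluorophenyl Alkyne

The source may hold more compounds than are shown below. What is called first, only, known or untested is meant among the compounds shown, and "the series" means these compounds.

Measured compounds:
compound 1, `Nc1ccc(C#Cc2c(F)cccc2F)cc1`: 55 nM
compound 2, `CN(C)c1ccc(C#Cc2ccc(F)cc2)cc1`: > 3000 nM
compound 3, `CN(C)c1ccc(C#Cc2ccc(F)cc2F)cc1`: 56 nM

In a functional assay on LS174T cells (Homo sapiens) for antiproliferative activity, with a stated time of 4 days (a higher number here means a weaker inhibitor, a lower number a stronger inhibitor), compound 1 gives 55 nM. Compound 3 gives 56 nM, which sits within the scatter of compound 1. The value of compound 2 is a limit, not a number (the limit of > 3000 nM in this assay, at which 1 of the 3 values shown sits). Compound 4, `CN(C)c1ccc(C#Cc2c(F)cccc2F)cc1`, differs from compound 1 in one place: dimethylamino in place of amino on an aromatic carbon. Within the data shown here, the only measured step, an at least 53-fold lower number from compound 2 to compound 3 (1.72 log units; beyond the scatter), concerns a fluoro for a hydrogen and so does not bear on this change. Compound 1 and compound 3 differ in two places, yet their values are indistinguishable. Among the measured compounds shown here, with no step on this change, the expectation is a 1.1-fold higher number from compound 1 to compound 4 (0.04 log units; within the scatter). Compound 4 is therefore estimated at 60 nM, between 15 nM and 400 nM.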

Compound 4, half-maximal inhibitory concentration: 23 nM
Beside the measured number, compound 4's estimate is 2.6-fold (0.42 log units) above it; measured number inside the range.
By their numbers in this assay, from the lowest: compound 4; then compounds 1 and 3 (each within the scatter of the next). At a limit, above all of these: compound 2.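

In this assay, dimethylamino in place of amino, on an aromatic carbon para to a large group, gives a 2.4-fold lower number from compound 1 to compound 4 (0.38 log units; beyond the scatter). So at this position the hydrogen-bond donor of amino is not needed for activity in these cells, and the larger dimethylamino group is accepted. Nothing measured here explains why the number falls.

The compounds shown leave open how methylamino, with one methyl group on the nitrogen, would compare at this position. Going by these compounds, how a longer chain such as diethylamino or a cyclic amine such as pyrrolidine would behave there also remains open.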